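The compounds below may be only part of what the source reports. "The series", "measured", "known", "first", "only" and "open" are said of these compounds alone.

Compound 3 `O=C1[C@@H](NS(=O)(=O)c2cc3nc(Cl)ccc3s2)CCN1Cc1cc2c[nH]ccc-2n1` stands highest of the three numbers in an assay on isolated protein for inhibition of coagulation factor X (Oryctolagus cuniculus), tested at 1 uM (a lower number here means less inhibition, a higher number more inhibition at the concentration tested (going by the name of the read-out)), where compound 3 gives 58%. Compound 1 `CC(C)(C)c1ccc(S(=O)(=O)N[C@H]2CCN(Cc3cc4cc[nH]cc-4n3)C2=O)cc1` gives 57%, within the scatter of compound 3, and compound 2 `O=C1[C@@H](NS(=O)(=O)c2cc3cccnc3s2)CCN1Cc1cc2c[nH]ccc-2n1` gives 18%, the furthest below. Within the data shown here, the only step that can be followed, a number 40 percentage points higher from compound 2 to compound 3 (beyond the scatter), exchanges the group on the sulfonyl sulfur, as does the step to compound 4 `CC(C)(C)c1ccc(S(=O)(=O)N[C@H]2CCN(Cc3cc4c[nH]ccc-4n3)C2=O)cc1`: a group of 10 heavy atoms (10 carbon; one six-membered aromatic ring of carbon only) in place of a group of 10 heavy atoms (7 carbon, 1 nitrogen, 1 sulfur, 1 chlorine; one five-membered aromatic ring with 1 hetero atom, one six-membered aromatic ring with 1 hetero atom), on a sulfonyl sulfur. Among the measured compounds shown here, no measured step shows this particular exchange on the core of compound 3, but compound 1 carries the same 4-(tert-butyl)phenyl group on a different core and gives 57%, close to compound 3. Compound 4 is therefore expected to give about 55%, between 35% and 75%. The step of a number 3 percentage points lower from compound 3 to compound 4 (within the scatter) is thus expected to stay within the scatter.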

Compound 4, a percentage reported as inhibition, at one concentration (the size of the read-out at that concentration, not a potency): 14%
Compound 4: middle estimate off by 41 percentage points, on the high side; measured number below the stated range.
By their numbers in this assay, from the lowest: compounds 4 and 2 (each within the scatter of the next); then compounds 1 and 3 (each within the scatter of the next).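

In this assay the 4-(tert-butyl)phenyl group on the sulfonyl sulfur does not match the chlorine-bearing group it replaces, giving a number 44 percentage points lower from compound 3 to compound 4 (beyond the scatter), and it stays level with the chlorine-free group of compound 2, as a number 4 percentage points lower from compound 2 to compound 4 (within the scatter) shows. Keeping 4-(tert-butyl)phenyl and changing only the group on the saturated chain carbon bound to an amide-type nitrogen in a ring gives a number 43 percentage points lower from compound 1 to compound 4 (beyond the scatter), so the sulfonyl group alone does not set the number. Nothing shown here explains these differences. On these data alone, whether a bromine or a methyl group in place of the chlorine would hold the inhibition stays open.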